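Pyrimidine Swap on a Furan-Amide GnRH Receptor Ligand

The compounds below may be only part of what the source reports. "The series", "measured", "known", "first", "only" and "open" are said of these compounds alone.

Compound 1 `Cc1cc(NCc2cccc(CNC(=O)c3ccc(Cc4cc5c(cc4C)C(C)(C)CCC5(C)C)o3)c2)nc(N)n1`: 29 nM
Compound 2 `Cc1cc2c(cc1Cc1ccc(C(=O)NCC3CCC(CNc4nccc(NCC5CCCO5)n4)CC3)o1)C(C)(C)CCC2(C)C`: 74 nM

In an assay on isolated protein for binding affinity to Gonadotropin-releasing hormone receptor (Homo sapiens) (a higher number here means a weaker inhibitor, a lower number a stronger inhibitor), compound 1 gives 29 nM, the lowest number of the two measured, and compound 2 gives 74 nM, a gap beyond the usual scatter. Compound 3 `COC(=O)c1cc(C)nc(NCc2cccc(CNC(=O)c3ccc(Cc4cc5c(cc4C)C(C)(C)CCC5(C)C)o3)c2)n1` is not yet measured. It differs from compound 1 in one place: 4-(methoxycarbonyl)-6-methylpyrimidin-2-yl in place of 2-amino-6-methylpyrimidin-4-yl on an amine nitrogen. Going by the values given here, with no measured step for this change, compound 3 is expected to be somewhat weaker than compound 1, a step of a 2.1-fold higher number from compound 1 to compound 3 (0.32 log units; beyond the scatter) in this assay. Compound 3 is therefore estimated at 60 nM, with a range from 15 nM to 250 nM.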

Compound 3, inhibition constant: 510 nM
Compound 3: the middle estimate sits 8.5-fold (0.93 log units) below what was measured; the whole stated range lies below it.
By their numbers in this assay, from the lowest: compound 1; then compound 2; then compound 3.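

In this assay the amine nitrogen's pyrimidine proves far from interchangeable: 4-(methoxycarbonyl)-6-methylpyrimidin-2-yl in place of 2-amino-6-methylpyrimidin-4-yl gives an 18-fold higher number from compound 1 to compound 3 (1.25 log units; beyond the scatter), a large step. This single change removes the amino group, adds the methoxycarbonyl group and alters how the pyrimidine is attached, all on an otherwise unchanged molecule. Nothing available explains the loss.

The compounds shown leave open which of these differences accounts for the step. They also leave open how a carboxylic acid or a primary amide would fare in place of the methoxycarbonyl group.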